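Swapping the aryl group: solubility from compound 2 to compound 3

This account rests on a few compounds, and the source may have more. Where it says the series, first, only, none or still open, it means among the compounds named here.

Compound 1, `Cc1cccc(Cl)c1-c1nc(CN2CCC(C(=O)NCCCN3CCC(C)(C)CC3)CC2)c(C)o1`: > 74 ug/mL
Compound 2, `Cc1oc(-c2c(Cl)cccc2C(F)(F)F)nc1CN1CCC(C(=O)NCCCN2C[C@H](C)C[C@H](C)C2)CC1`: 65.1 ug/mL

Of the compounds shown here, two have been measured in a physicochemical assay for solubility, in phosphate buffer, measured as kinetic solubility, at pH 7.4; a higher number here means a more soluble compound, a lower number a less soluble compound. Compound 1 `Cc1cccc(Cl)c1-c1nc(CN2CCC(C(=O)NCCCN3CCC(C)(C)CC3)CC2)c(C)o1` gives > 74 ug/mL, which is a limit of the assay and not a number. Among the compounds with values here, compound 2 `Cc1oc(-c2c(Cl)cccc2C(F)(F)F)nc1CN1CCC(C(=O)NCCCN2C[C@H](C)C[C@H](C)C2)CC1` gives 65.1 ug/mL, the only plain number available. Its value lies just under (the limit of > 74 ug/mL in this assay, at which 1 of the 2 values shown sits). Compound 3 `Cc1ccc(-c2nc(CN3CCC(C(=O)NCCCN4C[C@H](C)C[C@H](C)C4)CC3)c(C)o2)cc1C` differs from compound 2 in one place: 3,4-dimethylphenyl in place of 2-chloro-6-(trifluoromethyl)phenyl on an aromatic carbon. Within the data shown here, no step between measured compounds covers a change of this kind. The step of a 1.1-fold higher number from compound 2 to compound 3 (0.03 log units; within the scatter) is expected to be small, a slight rise that stays within the usual scatter. Compound 3 is therefore estimated at 70 ug/mL, with a range from 35 ug/mL to 140 ug/mL.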

Compound 3, solubility: > 71 ug/mL
Compound 3: no number, only a limit; the forecaster's own chance of this, stated with the estimate: 45%; middle value at least 1.0-fold (0.00 log units) from the limit.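

In this assay compound 3 gives > 71 ug/mL, which is a limit of the assay and not a number. Placing 3,4-dimethylphenyl where 2-chloro-6-(trifluoromethyl)phenyl stood gives an at least 1.0-fold higher number from compound 2 to compound 3 (0.03 log units; that floor lies within the scatter). This position therefore holds an aryl group carrying only carbon, with neither chlorine nor fluorine, and the reading still reaches the limit of the assay. As far as these compounds go, how far compound 3 lies past its limit stays open, so the true size of this step is unknown. Also open, from the compounds shown here alone, is how a phenyl ring bearing an amine or a carboxylic acid would read at this position.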